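From 2-methylphenyl to 3,4-dichlorophenyl: working notes

The compounds below may be only part of what the source reports. "The series", "measured", "known", "first", "only" and "open" are said of these compounds alone.

In a physicochemical assay for solubility, in phosphate buffer, at pH 7.4 (a higher number here means a more soluble compound, a lower number a less soluble compound), compound 1 (`CCOC(=O)c1c(-c2ccccc2C)[nH]c2cc(OC)ccc2c1=O`) stands at > 100000 nM as a limit of the assay, not a number. In this assay compound 2 (`CCOC(=O)c1c(-c2ccc(C(C)(C)C)cc2)[nH]c2cccc(OC)c2c1=O`) gives 1000 nM as a measured number. For the measured compounds named here, no step between measured compounds is available, so any expectation rests on these two readings alone.

Compound 3 (`CCOC(=O)c1c(-c2ccc(Cl)c(Cl)c2)[nH]c2cc(OC)ccc2c1=O`) keeps the core of compound 1 and exchanges one group: 3,4-dichlorophenyl in place of 2-methylphenyl, on the aromatic carbon next to the ring nitrogen (3,4-dichlorophenyl in place of 2-methylphenyl on an aromatic carbon).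

Going by the values given here, with compound 2 at 1000 nM as the only numbered reading, a downward move in this assay beyond the scatter is expected for this exchange, though its size is poorly fixed. The expected move is an at least 16-fold lower number from compound 1 to compound 3 (1.22 log units; beyond the scatter) on this estimate. Compound 3 is expected at 6000 nM (estimated range 1000 nM to 40000 nM).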

Compound 3, solubility: 17000 nM
Compound 3: the middle estimate sits 2.8-fold (0.45 log units) below what was measured; the range from low to high includes it.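

At the aromatic carbon next to the ring nitrogen, exchanging 2-methylphenyl for 3,4-dichlorophenyl on the core of compound 1 gives a readable step in this assay: an at least 5.8-fold lower number from compound 1 to compound 3 (0.76 log units; beyond the scatter). The value of compound 1 is a limit of the assay and not a number, so the step fixes only a minimum size: the limit of > 100000 nM in this assay, at which 1 of the 3 values shown sits. For the compounds shown here, compound 2 differs from compound 3 in more than one place and adds no step at this position.

The compounds shown do not separate the arrival of the two chlorine atoms from the departure of 2-methylphenyl. Also open, on these data alone, is how a phenyl group carrying an amine or a carboxylic acid would read at this carbon in this assay.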